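A few compounds are considered here, and "the series" means these few. Any claim that something is new, unique, unknown or untested is made for them only; others in the source may bear on it.

Measured in a functional assay on HeLa cells for agonist activity at 5-hydroxytryptamine receptor 6 (Homo sapiens), read by cAMP accumulation and immunoassay; on this read-out higher numbers stand for an effect only at larger amounts of compound and lower numbers for an effect already at smaller amounts:
compound 1 `O=S(=O)(c1ccccc1Cl)c1cn(C2CCCNC2)c2ncccc12` gives 50 nM
compound 2 `O=S(=O)(c1cccc(Cl)c1)c1cn(C2CCCNC2)c2ncccc12` gives 30 nM
compound 3 `O=S(=O)(c1cccc(Br)c1)c1cn(C2CCCNC2)c2ncccc12` gives 72 nM

Compound 3 carries the highest of the three numbers, though its gap to compound 1 is within the scatter; only the gap to compound 2, a 2.4-fold higher number from compound 2 to compound 3 (0.38 log units; beyond the scatter), lies beyond it. Compound 4 `O=S(=O)(c1cc(Cl)cc(Cl)c1)c1cn(C2CCCNC2)c2ncccc12` differs from compound 3 by 3,5-dichlorophenyl in place of 3-bromophenyl on a sulfonyl sulfur. For the measured compounds named here, two measured steps bear on this. Chloro for bromo is the reverse of a 2.4-fold higher number from compound 2 to compound 3 (0.38 log units; beyond the scatter), a modest move toward lower numbers. 3-Chlorophenyl for 2-chlorophenyl gave a 1.7-fold lower number from compound 1 to compound 2 (0.22 log units; within the scatter), within the scatter. Going by the values given here, no measured step covers a second chloro on the same ring, so that part carries no weight. The expectation for compound 4 in this assay is therefore a modest step to lower numbers, a 2.1-fold lower number from compound 3 to compound 4 (0.31 log units; beyond the scatter). Compound 4 is estimated at 35 nM, range 12 nM to 100 nM.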

Compound 4, half-maximal effective concentration: 297 nM
For compound 4 the middle estimate is 8.5-fold (0.93 log units) below the measured one, outside the stated range (above it).
By their numbers in this assay, from the lowest: compounds 2, 1 and 3 (each within the scatter of the next, the first and the last beyond it); then compound 4.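

In this assay, adding a second chloro to the aryl group on the sulfonyl sulfur gives a larger step than any earlier change there, a 9.9-fold higher number from compound 2 to compound 4 (1.00 log units; beyond the scatter). The 3,5-dichlorophenyl group also stands clearly apart from the two other aryl groups, with a 4.1-fold higher number from compound 3 to compound 4 (0.62 log units; beyond the scatter) and a 5.9-fold higher number from compound 1 to compound 4 (0.77 log units; beyond the scatter), so the single-halogen swaps gave no guide to this change. Nothing available explains this step.

Open, on these data alone, is how far this step depends on the second group being chloro. A methoxy or an amine in its place could separate the effect of the added group from that of chloro itself.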